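Removing a sulfonylurea nitrogen methyl in aortic assays

The source may report more compounds than this note shows. Statements on the series, on what has been measured and on what is new or still open speak of the compounds shown alone.

Values in a functional assay on thoracic aorta (Rattus norvegicus, strain Wistar), with a stated time of 15 min; on this read-out lower numbers stand for an effect already at smaller amounts and higher numbers for an effect only at larger amounts of compound:
- compound 1 `CC(NC(=O)NS(=O)(=O)c1ccc(Cl)cc1)c1cc(Br)ccc1OCc1ccccc1`: 57500 nM
- compound 2 `COc1ccc(Br)cc1C(C)NC(=O)NS(=O)(=O)c1ccc(C)cc1`: > 300000 nM (a limit, not a number)
- compound 3 `COc1ccc(Br)cc1C(C)NC(=O)N(C)S(=O)(=O)c1ccc(Cl)cc1`: 19100 nM

Compound 3 has the lowest of the two true numbers. Compound 1, at 57500 nM, stands higher, a gap beyond the usual scatter. Compound 4 `COc1ccc(Br)cc1C(C)NC(=O)NS(=O)(=O)c1ccc(Cl)cc1` differs from compound 3 by having hydrogen in place of methyl on an amide-type nitrogen. Among the measured compounds shown here, no measured pair isolates this change in this assay, so its size is uncertain. A move to a higher number beyond the scatter is expected, since compound 1 at 57500 nM also carries hydrogen there. Compound 2 also carries hydrogen there, and its > 300000 nM is a limit. The expected change is a 2.4-fold higher number from compound 3 to compound 4 (0.37 log units; beyond the scatter). For compound 4 the estimate is 45000 nM, with an expected range from 15000 nM to 200000 nM.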

Compound 4, half-maximal effective concentration: 80900 nM
For compound 4 the middle estimate is 1.8-fold (0.25 log units) below the measured one; the measured number falls inside the stated range.
By their numbers in this assay, from the lowest: compound 3; then compounds 1 and 4 (each within the scatter of the next). At a limit, above all of these: compound 2.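

In this assay, among the compounds shown here, the first pair to isolate this nitrogen gives a 4.2-fold higher number from compound 3 to compound 4 (0.63 log units; beyond the scatter), so methyl in place of hydrogen on the amide-type nitrogen does change the read-out. Chloro in place of methyl on an aromatic carbon gives an at least 3.7-fold lower number from compound 2 to compound 4 (0.56 log units; beyond the scatter), while hydrogen in place of phenyl on a saturated chain carbon bound to an oxygen on an aromatic ring gives a 1.4-fold higher number from compound 1 to compound 4 (0.15 log units; within the scatter). The value of compound 2 is a limit, not a number: the limit of > 300000 nM in this assay, at which 1 of the 4 values shown sits.

From the compounds shown here alone, whether an ethyl group or a longer chain on that nitrogen would lower the number further remains open. So does whether methyl there gives a similar step on the core of compound 1.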